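The source may report more compounds than this note shows. Statements on the series, on what has been measured and on what is new or still open speak of the compounds shown alone.

Measured so far in a functional assay on K562 cells (Homo sapiens) for cytotoxicity, read by MTT assay, with a stated time of 48 h; on this read-out higher numbers stand for weaker inhibition and lower numbers for stronger inhibition:
- compound 1, `O=C(CN[C@H]1CCN(S(=O)(=O)Cc2ccccc2)C1)N1CCN(Cc2ccccc2F)CC1`: 12600 nM
- compound 2, `O=C(CN[C@H]1CCN(S(=O)(=O)Cc2ccccc2)C1)N1CCN(Cc2c(Cl)cccc2Cl)CC1`: 28400 nM
- compound 3, `COc1cccc(CN2CCN(C(=O)CN[C@H]3CCN(S(=O)(=O)Cc4ccccc4)C3)CC2)c1`: 60800 nM

Compound 1 gives the lowest number of the three in this assay; compound 2 is its nearest neighbour and compound 3 lies furthest away. Both steps away from compound 1 move the number up: a 2.3-fold higher number from compound 1 to compound 2 (0.35 log units; beyond the scatter) and a 4.8-fold higher number from compound 1 to compound 3 (0.68 log units; beyond the scatter). Between the two analogues the gap is a 2.1-fold higher number from compound 2 to compound 3 (0.33 log units; beyond the scatter).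

Compound 4, `COc1ccc(CN2CCN(C(=O)CN[C@H]3CCN(S(=O)(=O)Cc4ccccc4)C3)CC2)cc1`, is not yet measured. Relative to compound 1 the change is 4-methoxyphenyl in place of 2-fluorophenyl on a saturated chain carbon bound to an amine nitrogen in a ring. Among the measured compounds shown here, the step that bears most directly on it is the one to compound 3, where 3-methoxyphenyl in place of 2-fluorophenyl raised the number by a 4.8-fold higher number from compound 1 to compound 3 (0.68 log units; beyond the scatter); the step to compound 2, a 2.3-fold higher number from compound 1 to compound 2 (0.35 log units; beyond the scatter), points the same way but is smaller. Within these three compounds each replacement of the 2-fluorophenyl raised the number, so a higher number for compound 4 is expected, though the 4-methoxyphenyl itself is untested and the size is uncertain. The expected step is a 2.8-fold higher number from compound 1 to compound 4 (0.44 log units; beyond the scatter). Compound 4 is therefore estimated at 35000 nM, with a range from 15000 nM to 80000 nM.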

Compound 4, half-maximal inhibitory concentration: 50900 nM
The estimate for compound 4 lay 1.5-fold (0.16 log units) below the measured number; the range from low to high includes it.
By their numbers in this assay, from the lowest: compound 1; then compounds 2, 4 and 3 (each within the scatter of the next, the first and the last beyond it).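

In this assay, the 4-methoxyphenyl group gives a 4.0-fold higher number from compound 1 to compound 4 (0.61 log units; beyond the scatter) and so confirms that compound 1 keeps the lowest number of the series, with its steps to all three analogues beyond the scatter. The position of the methoxy group on the ring makes no readable difference, as a 1.2-fold lower number from compound 3 to compound 4 (0.08 log units; within the scatter) lies within the scatter, and a 1.8-fold higher number from compound 2 to compound 4 (0.25 log units; within the scatter) leaves the 4-methoxyphenyl and 2,6-dichlorophenyl groups likewise unseparated. No measurement here bears on the cause of these steps.

The compounds shown leave open whether the lower number of compound 1 belongs to the fluorine itself or to where it sits on the ring, a question that unsubstituted phenyl, 4-fluorophenyl and 2-methoxyphenyl groups would address. Also open, on these data alone, is how an amine or carboxylic acid on this ring would read.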